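Stereochemistry Drives Norepinephrine Transporter Binding in a Piperidine Series

A few compounds are considered here, and "the series" means these few. Any claim that something is new, unique, unknown or untested is made for them only; others in the source may bear on it.

Compound 1 `CC(=O)OCCSC[C@H]1CN(C)CC[C@H]1c1ccc(Cl)cc1` gives 610 nM in an assay on a subcellular fraction from brain with Norepinephrine transporter (Rattus norvegicus) as the target; a lower number here means a stronger inhibitor, a higher number a weaker inhibitor. Compound 2 `CC(=O)OCCSC[C@@H]1CN(C)CC[C@H]1c1ccc(Cl)cc1` gives 52 nM in this assay. Compound 3 `CN1CC[C@@H](c2ccc(Cl)cc2)[C@H](CSCCOC(=O)c2ccccc2)C1` gives 56 nM in this assay.

Compound 3 stands second highest of the three numbers: its nearest neighbour is compound 2, which lies within the scatter of it, and its furthest is compound 1, which lies beyond the scatter. The step of a 1.1-fold higher number from compound 2 to compound 3 (0.03 log units; within the scatter) shows that swapping phenyl for methyl on the carbonyl carbon leaves the number essentially unchanged.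

Compound 4 `CN1CC[C@@H](c2ccc(Cl)cc2)[C@@H](CSCCOC(=O)c2ccccc2)C1` differs from compound 3 in the following way: the two compounds have the same atoms and bonds and differ only in configuration as drawn: 1 of 2 stereo elements differ; a stereocentre at a saturated ring carbon is drawn S in compound 3 and R in compound 4. For the measured compounds named here, the one measured step that bears on this is a 12-fold lower number from compound 1 to compound 2 (1.07 log units; beyond the scatter), and it is large because the fact that compounds 1 and 2 differ only in the configuration as drawn — that pair differs only in the configuration drawn at the same kind of saturated ring carbon. Since compound 4 reverses the configuration that compound 3 shares with compound 2, the step of an 11-fold higher number from compound 3 to compound 4 (1.03 log units; beyond the scatter) is expected to run in the opposite direction to that measured step and to be of comparable size, well beyond the scatter. Compound 4 is therefore estimated at 600 nM, with a range of 250 nM to 1500 nM.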

Compound 4, inhibition constant: 143 nM
The estimate for compound 4 lay 4.2-fold (0.62 log units) above the measured number; measured number outside the range, below it.
By their numbers in this assay, from the lowest: compounds 2 and 3 (each within the scatter of the next); then compound 4; then compound 1.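

With phenyl on the carbonyl carbon, the configuration at the saturated ring carbon still matters, but a 2.6-fold higher number from compound 3 to compound 4 (0.41 log units; beyond the scatter) is a smaller step than a 12-fold lower number from compound 1 to compound 2 (1.07 log units; beyond the scatter), and nothing but that configuration can account for it: the fact that compounds 3 and 4 differ only in the configuration as drawn. The new result also shows that phenyl in place of methyl is not neutral on every core, since a 4.3-fold lower number from compound 1 to compound 4 (0.63 log units; beyond the scatter) contrasts with the flat step seen on the core of compound 2: the same change on two cores in this assay, a 1.1-fold higher number (0.03 log units; within the scatter) from compound 2 to compound 3 and a 4.3-fold lower number (0.63 log units; beyond the scatter) from compound 1 to compound 4, 4.6-fold (0.66 log units) apart, beyond the scatter of two such steps. The two changes therefore do not act independently in this assay: the exchange on the carbonyl carbon changes the number with the ring carbon drawn R, and the configuration step is smaller with phenyl than with methyl, although the compounds with that carbon drawn S give the lower number in both pairs.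

The compounds shown leave open whether this interplay is particular to phenyl or would also appear with other groups on the carbonyl carbon, such as ethyl or cyclohexyl. They also leave open whether an amide in place of the ester would show the same dependence on configuration.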